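Swapping the pendant aryl group on a pyridine-based core

The source may hold more compounds than are shown below. What is called first, only, known or untested is meant among the compounds shown, and "the series" means these compounds.

Of the compounds shown here, three sharing one core have been measured in an assay on CHO cells for inhibition of Glucagon receptor (Homo sapiens), tested at 20 uM; on this read-out higher numbers stand for more inhibition at the one concentration tested (going by the name of the read-out) and lower numbers for less inhibition. Compound 1, `CCCCCc1c(C(C)C)nc(C(C)C)c(CO)c1-c1ccc(CC)cc1`, gives 42%. Compound 3, `CCCCCc1c(C(C)C)nc(C(C)C)c(CO)c1-c1cccc(C(F)(F)F)c1`, gives 25%, and compound 2, `CCCCCc1c(C(C)C)nc(C(C)C)c(CO)c1-c1cccc2ccccc12`, gives 6%. Compound 1 therefore stands highest of the three: compound 3 sits a good way below it, beyond the usual scatter, and compound 2 sits far below it, also beyond the scatter. Going by the values given here, both of the lower compounds carry a larger or more heavily substituted aryl group in place of the 4-ethylphenyl of compound 1, though with only three compounds no firm rule can be drawn.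

The next compound, compound 4, `CCCCCc1c(C(C)C)nc(C(C)C)c(CO)c1-c1ccccc1CO`, has not been tested yet. It differs from compound 1 in a single spot: 2-(hydroxymethyl)phenyl in place of 4-ethylphenyl on an aromatic carbon. The group that leaves carries no hydrogen-bond donor or acceptor, while the entering 2-(hydroxymethyl)phenyl carries one of each, and the substituent moves from the 4-position to the 2-position of the phenyl ring.

Given that every departure from compound 1 seen so far has lowered the read-out, compound 4 is expected to fall somewhat, with an expected step of a number 17 percentage points lower from compound 1 to compound 4 (beyond the scatter). Compound 4 is estimated at 25%, in a range from 5% to 48%.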

Compound 4, a percentage reported as inhibition, at one concentration (the size of the read-out at that concentration, not a potency): 44%
Compound 4: middle estimate off by 19 percentage points, on the low side; low and high end bracket the measured number.
By their numbers in this assay, from the lowest: compound 2; then compound 3; then compounds 1 and 4 (each within the scatter of the next).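

In this assay, putting 2-(hydroxymethyl)phenyl in place of 4-ethylphenyl gives a number 2 percentage points higher from compound 1 to compound 4 (within the scatter), so this position accepts an aryl group that carries a hydrogen-bond donor and a hydrogen-bond acceptor and has its substituent at a different place on the phenyl ring, with no change beyond the scatter. Compound 2 and compound 3 both lie beyond the scatter below compound 1, whereas compound 4 does not, which shows that swapping the aryl group here need not lower the read-out. Nothing measured here bears on why these two groups give such similar numbers.

Compound 4 brings in the hydroxymethyl group and moves the substituent on the phenyl ring in a single step, so the compounds shown leave open what each change does alone, a question that 2-ethylphenyl and 4-(hydroxymethyl)phenyl could separate. They also leave open how a phenyl ring carrying an amine, a carboxylic acid or a longer hydroxyalkyl chain would behave at this position.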